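The source may report more compounds than this note shows. Statements on the series, on what has been measured and on what is new or still open speak of the compounds shown alone.

Three compounds have been measured so far:

compound 1, `O=c1ccn(CCN2CCCCC2)c(CO)c1O`, 0.019
compound 2, `CCN(CC)CCn1ccc(=O)c(O)c1C`, 0.059
compound 3, `O=c1cc(CN2CCCCC2)n(CCN2CCCCC2)cc1O`, 1.84

The assay in question is a physicochemical assay for lipophilicity; a lower number here means a more polar compound, a higher number a more lipophilic compound. Among the three numbers, compound 1 holds the lowest; in this assay compound 1 gives 0.019. Its nearest neighbour is compound 2, whose value in this assay of 0.059 lies within the usual scatter of it, so the two cannot be told apart. Within the data shown here, the one value that does stand clearly apart belongs to compound 3, which in this assay gives 1.84, well beyond the scatter above compound 1. Compound 3 differs from compound 1 in more than one place, so its number says nothing on its own about any single change.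

The compound not yet measured is compound 4, `CCc1c(O)c(=O)ccn1CCN1CCCCC1`. It is reached from compound 1 by a single change:

methyl in place of hydroxy on a saturated chain carbon bound to an aromatic carbon

Among the measured compounds shown here, no measured pair differs in one place only, so no measured step guides the size of this one. A hydroxy group that leaves and a methyl that enters is expected to move the number upward, beyond the scatter, and the step from compound 1 to compound 4 is estimated at a number 1.18 log units higher from compound 1 to compound 4 (beyond the scatter). For compound 4 the value in this assay is estimated at 1.2. The estimate for compound 4 is thought to lie between 0.6 and 1.8.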

Compound 4, partition coefficient: 0.946
Estimate against measurement, compound 4: 0.25 log units above, within the range that was stated.
By their numbers in this assay, from the lowest: compounds 1 and 2 (each within the scatter of the next); then compound 4; then compound 3.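

In this assay there is a number 0.93 log units higher from compound 1 to compound 4 (beyond the scatter) when methyl takes the place of hydroxy on a saturated chain carbon bound to an aromatic carbon. Among these compounds, the same difference, cut one bond further out, reads hydroxymethyl to ethyl, and it gives this position its first measured size for a change in one place, which the earlier compounds could not supply as none of them formed such a pair. Nothing shown accounts for the size of this step.

Among the compounds shown here, whether an amine, a carboxylic acid, a methoxy group or a longer chain on this carbon would give a step of similar size or direction remains open, as hydroxy and methyl are the only two groups compared here in one place. From the compounds shown here alone, it also remains open whether the same change would give a similar step on a compound with a different side chain, as the step rests on this single pair.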